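Swapping an aryl amide for a carboxyethyl amide

A few compounds are considered here, and "the series" means these few. Any claim that something is new, unique, unknown or untested is made for them only; others in the source may bear on it.

Compound 1 `CCn1c(C(=O)NCCN(C)C)ccc1C(CC)(CC)c1ccc(OCCC(O)(CC)CC)c(C)c1` gives 1140 nM in a functional assay on Caco-2 cells (Homo sapiens) for antiproliferative activity, read by MTT assay, with a stated time of 48 h; a lower number here means a stronger inhibitor, a higher number a weaker inhibitor. Compound 2 `CCn1c(C(=O)Nc2ccc(OC(F)(F)F)cc2)ccc1C(CC)(CC)c1ccc(OCCC(O)(CC)CC)c(C)c1` reaches only the detection limit of this assay, > 50000 nM, which is a limit rather than a measured number. The step of an at least 43-fold higher number from compound 1 to compound 2 (1.64 log units; beyond the scatter) is therefore known only at its lower bound, because compound 2 sits at the limit of > 50000 nM in this assay, at which 1 of the 2 values shown sits.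

Compound 3 `CCn1c(C(=O)NC(C)C(=O)O)ccc1C(CC)(CC)c1ccc(OCCC(O)(CC)CC)c(C)c1` differs from compound 2 by 1-carboxyethyl in place of 4-(trifluoromethoxy)phenyl on an amide-type nitrogen. Within the data shown here, only the step from compound 1 to compound 2 bears on this change: a large rise in the number when a short chain gave way to the aryl group. Returning to a short chain, now ending in a carboxylic acid rather than a dimethylamino group, a fall is expected, an at least 2.5-fold lower number from compound 2 to compound 3 (0.39 log units; beyond the scatter). Compound 3 is estimated at 20000 nM, between 5000 nM and 60000 nM.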

Compound 3, half-maximal inhibitory concentration: 46500 nM
Compound 3: the middle estimate sits 2.3-fold (0.37 log units) below what was measured, and the stated range covers the measured number.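

Having a short chain on the amide-type nitrogen is not enough to keep activity: with 1-carboxyethyl in place of 2-(dimethylamino)ethyl, the result is a 41-fold higher number from compound 1 to compound 3 (1.61 log units; beyond the scatter), so what the chain carries matters here. Replacing the aryl group reads only as an at least 1.0-fold lower number from compound 2 to compound 3 (0.03 log units; that floor lies within the scatter), which puts the two compounds in no order. Compound 2 stands at a limit, not a measured number: the limit of > 50000 nM in this assay, at which 1 of the 3 values shown sits.

From the compounds shown here alone, whether the amine in compound 1 is what matters stays open. A plain ethyl chain or a longer chain ending in a dimethylamino group would help to settle this.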